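Cytotoxicity across lactam substituents: compound 3 to compound 4

The source may hold more compounds than are shown below. What is called first, only, known or untested is meant among the compounds shown, and "the series" means these compounds.

Measured compounds:
Compound 1, `O=C1CC(c2cnco2)CN1c1cnn2c1CN(C(=O)Nc1cc(F)c(F)c(F)c1)C(C1CC1)C2`, gives 139000 nM in a toxicity assay on HepG2 2.2.15 cells (Homo sapiens) for cytotoxicity, read by CellTiter-Glo; a higher number here means that more compound is tolerated, a lower number that less compound is tolerated.
Compound 2, `O=C1CC(c2ccccn2)CN1c1cnn2c1CN(C(=O)Nc1cc(F)c(F)c(F)c1)C(C1CC1)C2`, gives 96200 nM in this assay.
Compound 3, `O=C1CC(c2cnc(C(F)(F)F)s2)CN1c1cnn2c1CN(C(=O)Nc1cc(F)c(F)c(F)c1)C(C1CC1)C2`, gives 38500 nM in this assay.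

Compound 3 stands lowest of the three numbers in this assay. Its nearest neighbour is compound 2, with a 2.5-fold lower number from compound 2 to compound 3 (0.40 log units; beyond the scatter), and the furthest is compound 1, with a 3.6-fold lower number from compound 1 to compound 3 (0.56 log units; beyond the scatter); both steps lie beyond the scatter. The step of a 1.4-fold lower number from compound 1 to compound 2 (0.16 log units; within the scatter) lies within the scatter.

Compound 4, `O=C1CC(c2ncc(F)cn2)CN1c1cnn2c1CN(C(=O)Nc1cc(F)c(F)c(F)c1)C(C1CC1)C2`, differs from compound 3 in one place: 5-fluoropyrimidin-2-yl in place of 2-(trifluoromethyl)-1,3-thiazol-5-yl on a saturated ring carbon. The two steps that bear on this change are those arriving at compound 3, a 3.6-fold lower number from compound 1 to compound 3 (0.56 log units; beyond the scatter) and a 2.5-fold lower number from compound 2 to compound 3 (0.40 log units; beyond the scatter), each a modest lowering on moving to the 2-(trifluoromethyl)-1,3-thiazol-5-yl group. Replacing that group with 5-fluoropyrimidin-2-yl, which like pyridin-2-yl is a six-membered aromatic ring, should reverse most of that lowering and give a modest higher number in this assay. Going by the values given here, no measured compound carries the 5-fluoropyrimidin-2-yl group itself, so the range is kept wide. Compound 4 is therefore expected to show a 2.3-fold higher number from compound 3 to compound 4 (0.37 log units; beyond the scatter). The estimated value for compound 4 is 90000 nM, within a range from 40000 nM to 200000 nM.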

Compound 4, half-maximal cytotoxic concentration: 115000 nM
Compound 4: the middle estimate sits 1.3-fold (0.11 log units) below what was measured; the measured number falls inside the stated range.
By their numbers in this assay, from the lowest: compound 3; then compounds 2, 4 and 1 (each within the scatter of the next).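

In this assay, 5-fluoropyrimidin-2-yl on the saturated ring carbon does not carry the lowering seen with 2-(trifluoromethyl)-1,3-thiazol-5-yl, with a 3.0-fold higher number from compound 3 to compound 4 (0.48 log units; beyond the scatter) in this change, and compound 3 is now the only one of the four whose steps to all the others lie beyond the scatter. The new group cannot be separated from the other two aromatic rings at this position, with a 1.2-fold higher number from compound 2 to compound 4 (0.08 log units; within the scatter) against pyridin-2-yl and a 1.2-fold lower number from compound 1 to compound 4 (0.08 log units; within the scatter) against 1,3-oxazol-5-yl, so these three substituents, on five- and six-membered rings, read alike in this series. No measurement at hand explains why compound 3 stands apart from the other three.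

Whether the lowering follows the trifluoromethyl group or the 1,3-thiazole ring stays open; no compound shown carries one without the other. Also open, as far as these compounds go, is how an amine, a carboxylic acid or a longer alkyl chain on the same saturated ring carbon would read in this assay and whether any such group would move the number away from the level shared by compound 1, compound 2 and compound 4.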